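A few compounds are considered here, and "the series" means these few. Any claim that something is new, unique, unknown or untested is made for them only; others in the source may bear on it.

Working notes on the thiosemicarbazone series in a functional assay on MOLT-4 cells (Homo sapiens), with a stated time of 72 h; a higher number here means a weaker inhibitor, a lower number a stronger inhibitor.

Compound 1 `O=C1Nc2ccc(Cl)cc2/C1=N/NC(=S)Nc1ccc(Cl)cc1` carries a hydrogen on the amide-type nitrogen in the ring and gives 64000 nM. Going by the values given here, compound 3 `O=C1/C(=N\NC(=S)Nc2ccc(Cl)cc2)c2cc(Cl)ccc2N1Cc1ccc(Cl)cc1` carries a 4-chlorobenzyl there and gives 58000 nM, which is the second highest of the three numbers so far; the change a 1.1-fold lower number from compound 1 to compound 3 (0.04 log units; within the scatter) stays within the scatter. Compound 2 `O=C1/C(=N\NC(=S)Nc2ccc(Cl)cc2)c2cc(F)ccc2N1Cc1ccc(F)cc1`, with fluoro on the core and a 4-fluorobenzyl, gives 47000 nM; its number and that of compound 3 lie within the scatter of each other, so nothing can be said about an order between them.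

Compound 4 `O=C1/C(=N\NC(=S)Nc2ccc(Cl)cc2)c2cc(Cl)ccc2N1Cc1ccc(F)cc1` differs from compound 3 by one change: fluoro in place of chloro on an aromatic carbon. Among the compounds with values here, no measured step covers exactly this exchange. Within the data shown here, the only measured step, from compound 1 to compound 3, was within the scatter, and the three numbers measured so far all sit within the scatter of one another, whatever the halogen pattern. On that basis no movement beyond the scatter is expected in this assay.

The estimate for compound 4 is a step of a 1.1-fold lower number from compound 3 to compound 4 (0.05 log units; within the scatter) that is expected to stay within the scatter. Compound 4 is therefore expected to give about 52000 nM, with a range from 28000 nM to 95000 nM.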

Compound 4, half-maximal inhibitory concentration: 48000 nM
Beside the measured number, compound 4's estimate is 1.1-fold (0.03 log units) above it; low and high end bracket the measured number.
By their numbers in this assay, from the lowest: compounds 2, 4, 3 and 1 (each within the scatter of the next).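

In this assay, going by these compounds alone, fluoro in place of chloro on the aromatic carbon of the 4-chlorobenzyl group gives the first direct reading of a halogen exchange at this position, and the step (a 1.2-fold lower number from compound 3 to compound 4 (0.08 log units; within the scatter)) stays within the scatter. The other single exchange now readable, chloro in place of fluoro on an aromatic carbon of the core (a 1.0-fold higher number from compound 2 to compound 4 (0.01 log units; within the scatter)), also stays within the scatter, as does 4-fluorobenzyl in place of hydrogen on the amide-type nitrogen in the ring (a 1.3-fold lower number from compound 1 to compound 4 (0.12 log units; within the scatter)), so this substituent joins 4-chlorobenzyl in moving the number by no readable amount. No supporting evidence bears on this result.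

The compounds shown carry only chloro or fluoro at this position, so it remains open whether a methoxy group, an amine or a carboxylic acid there would give a step beyond the scatter. As far as these compounds go, it also remains open whether a longer chain in place of the benzyl group on the ring nitrogen would move the number in this assay at all.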